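Beta-substituted acrylamide variant in the A549 antiproliferation series

The source may hold more compounds than are shown below. What is called first, only, known or untested is meant among the compounds shown, and "the series" means these compounds.

For the measured compounds named here, compound 2 `C=CC(=O)Nc1cc(Nc2nc(C)cc(-c3cn(C)c4ccccc34)n2)c(OC)cc1N(C)CCN(C)C` is the only member of the series with a numerical result in a functional assay on A549 cells (Homo sapiens) for antiproliferative activity, read by MTT assay, with a stated time of 72 h; on this read-out higher numbers stand for weaker inhibition and lower numbers for stronger inhibition: in this assay compound 2 gives 2910 nM. Compound 1 `COc1cc(N(C)CCN(C)C)c(NC(=O)C(Cl)=C(Cl)Cl)cc1Nc1nccc(-c2cn(C)c3ccccc23)n1`, which carries a trichlorovinyl amide in place of the acrylamide and lacks the methyl on the shared core, returns only a limit; in this assay compound 1 gives > 50000 nM, which is a limit of the assay and not a number (the limit of > 50000 nM in this assay, at which 1 of the 2 values shown sits). Going by the values given here, no step between measured compounds is therefore available.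

Compound 3 `CCC/C=C\C(=O)Nc1cc(Nc2nc(C)cc(-c3cn(C)c4ccccc34)n2)c(OC)cc1N(C)CCN(C)C` is the untested analogue of compound 2 differing in one place: pent-1-en-1-yl in place of vinyl on a carbonyl carbon. Among the compounds with values here, with no measured step to lean on, the expectation for this assay is a step from compound 2 to compound 3 towards weaker inhibition, beyond the scatter but well short of the limit, estimated as a 4.1-fold higher number from compound 2 to compound 3 (0.62 log units; beyond the scatter). Compound 3 is accordingly expected to give about 12000 nM in this assay, with a plausible span from 3000 nM to 50000 nM.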

Compound 3, half-maximal inhibitory concentration: 329 nM
Estimate against measurement, compound 3: 36-fold (1.56 log units) above, and the stated range ends above it.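

On a carbonyl carbon whose other neighbour is an amide-type nitrogen, the series now has its first readable step in this assay: an 8.8-fold lower number from compound 2 to compound 3 (0.95 log units; beyond the scatter). The earlier compounds gave no such reading, so this place is now shown to tolerate more than vinyl, and pent-1-en-1-yl in place of vinyl gives stronger inhibition, beyond the usual scatter. No measurement shown accounts for the size or the direction of this step, so the change is recorded here without a cause.

A single step cannot show whether the gain follows chain length, and the compounds shown leave open how a shorter prop-1-en-1-yl, a longer oct-1-en-1-yl chain or a chain ending in a dimethylamine would read at this place. In this assay compound 1 gives > 50000 nM, which is a limit of the assay and not a number, and as compound 1 differs from the other compounds in more than one place, the trichlorovinyl amide cannot yet be placed on the same scale.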